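The compounds below may be only part of what the source reports. "The series", "measured", "known", "first", "only" and "open" are said of these compounds alone.

Compound 1, `COC(c1cc(Cl)c2c(c1Cl)C(=O)N(Cc1c(C)cc(C)[nH]c1=O)CC2)C1CCOC1`, gives 1100 nM; 494 nM; 47 nM; 7 nM (4 entries) in an assay on cells for inhibition of histone-lysine N-methyltransferase EZH2 (Homo sapiens), read by ELISA, with a stated time of 72 h; a higher number here means a weaker inhibitor, a lower number a stronger inhibitor. Compound 2, `Cc1cc(C)c(CN2CCc3c(Cl)cc([C@H](CO)[C@H]4CCCO4)c(Cl)c3C2=O)c(=O)[nH]1`, gives 40 nM in this assay.

Within the data shown here, compound 1 is the only compound here measured more than once, and its entries spread widely, (the several entries of compound 1 in this assay, 1100 nM; 494 nM; 47 nM; 7 nM (4 entries)), so a single reading for any compound should be held loosely. Compound 2 stands on one number in this assay, with a further entry that did not yield a single value. Compound 3, `Cc1cc(C)c(CN2CCc3c(Cl)cc([C@H](CO)[C@@H]4CCCO4)c(Cl)c3C2=O)c(=O)[nH]1`, shares everything with compound 2 except configuration: the two compounds have the same atoms and bonds and differ only in configuration as drawn: 1 of 2 stereo elements differ; a stereocentre at a saturated ring carbon is drawn R in compound 2 and S in compound 3. Among the measured compounds shown here, no step between measured compounds is available to calibrate a change of configuration at this position, so the direction rests on general expectation only. A modest step toward weaker inhibition is expected, a 2.0-fold higher number from compound 2 to compound 3 (0.30 log units; within the scatter), likely within or only a little beyond the usual scatter. Compound 3 is therefore estimated at 80 nM in this assay, with a range from 20 nM to 400 nM.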

Compound 3, half-maximal inhibitory concentration in the histone-lysine N-methyltransferase EZH2 assay: 41 nM
The estimate for compound 3 lay 2.0-fold (0.29 log units) above the measured number, within the range that was stated.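

In the histone-lysine N-methyltransferase EZH2 assay compound 2 gives 40 nM and compound 3 gives 41 nM. Among these compounds, in the histone-lysine N-methyltransferase EZH2 assay the change of configuration at this saturated ring carbon comes to a 1.0-fold higher number from compound 2 to compound 3 (0.01 log units; within the scatter), which gives the first calibrated step at this position and leaves compound 2 and compound 3 indistinguishable, whether the stereocentre is drawn R or S. In a physicochemical assay for solubility, measured as kinetic solubility (a higher number here means a more soluble compound, a lower number a less soluble compound), compound 2 gives 430000 nM and compound 3 gives 400000 nM. In the physicochemical assay the same change comes to a 1.1-fold lower number from compound 2 to compound 3 (0.03 log units; within the scatter), so neither read-out separates the pair. The comparison rests on single readings, and the only repeated compound shows how loosely such readings should be held: the several entries of compound 1 in the histone-lysine N-methyltransferase EZH2 assay, 1100 nM; 494 nM; 47 nM; 7 nM (4 entries)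

The compounds shown leave open whether the second stereo element, drawn alike in compound 2 and compound 3, would prove as indifferent to inversion as this one. They also leave open how either read-out would respond if an amine or a carboxylic acid stood in place of the hydroxyl group.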